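Removing the Pyrazole: What the Bare Amino Compound Gives

The compounds below may be only part of what the source reports. "The series", "measured", "known", "first", "only" and "open" are said of these compounds alone.

Three measured compounds share one core and differ only in what sits on the nitrogen on the aromatic ring. In an assay on isolated protein for inhibition of Leucine-rich repeat serine/threonine-protein kinase 2 variant G2019S (Homo sapiens), read by TR-FRET and LanthaScreen, with stated times of 50 min and 30 min, in the presence of a further agent that is not named here (a higher number here means a weaker inhibitor, a lower number a stronger inhibitor), compound 1 `Cc1nn(CC2(O)COC2)cc1Nc1nc(N)c2c(C#N)c(N3CCC[C@H]3C)n(C)c2n1` gives 51 nM, compound 2 `Cc1nn(C)cc1Nc1nc(N)c2c(C#N)c(N3CCC[C@H]3C)n(C)c2n1` gives 30 nM, and compound 3 `C[C@@H]1CCCN1c1c(C#N)c2c(N)nc(Nc3cn[nH]c3)nc2n1C` gives 6 nM, the lowest number of the three and beyond the scatter from both others. The step of a 1.7-fold lower number from compound 1 to compound 2 (0.23 log units; within the scatter) puts hydrogen in place of 3-hydroxyoxetan-3-yl on a saturated chain carbon and changes little. The step of a 5.0-fold lower number from compound 2 to compound 3 (0.70 log units; beyond the scatter) puts 1H-pyrazol-4-yl in place of 1,3-dimethyl-1H-pyrazol-4-yl and lowers the number modestly. Compound 4 `C[C@@H]1CCCN1c1c(C#N)c2c(N)nc(N)nc2n1C` goes much further: hydrogen in place of 1H-pyrazol-4-yl on a nitrogen on an aromatic ring. Going by the values given here, no measured step removes the whole five-membered ring, so the two known steps are only a weak guide; they show that paring the ring down lowers the number or leaves it unchanged, not what its complete loss costs. Among the compounds with values here, since the group removed is the one whose trimming produced the only step beyond the scatter, compound 3 to compound 4 is expected to raise the number in this assay by a considerable step, estimated as a 100-fold higher number from compound 3 to compound 4 (2.00 log units; beyond the scatter). For compound 4 the expected value is 600 nM, within a range from 100 nM to 4000 nM.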

Compound 4, half-maximal inhibitory concentration: 217 nM
The estimate for compound 4 lay 2.8-fold (0.44 log units) above the measured number; the range from low to high includes it.
By their numbers in this assay, from the lowest: compound 3; then compounds 2 and 1 (each within the scatter of the next); then compound 4.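

In this assay the ring as a whole turns out to count at this nitrogen, and not only the methyl groups it may carry: hydrogen in place of 1H-pyrazol-4-yl gives a 36-fold higher number from compound 3 to compound 4 (1.56 log units; beyond the scatter), the largest step seen among these compounds. The loss does not depend on starting from the unsubstituted ring, since hydrogen in place of 1,3-dimethyl-1H-pyrazol-4-yl gives a 7.2-fold higher number from compound 2 to compound 4 (0.86 log units; beyond the scatter), a modest step in the same direction, so even the dimethylated ring gives a lower number than the bare amino group. Nothing in the data given accounts for these differences.

The compounds shown leave open whether another group on this nitrogen, such as a phenyl ring, a pyridine or a simple acetyl, would bring the number back toward that of compound 3 or leave it nearer that of compound 4. They also leave open which of the two methyl groups matters, as both leave together from compound 2 to compound 3, and a pyrazole carrying only one of them would separate the two.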